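Cytotoxicity notes on the aryl-amine substituent series

A few compounds are considered here, and "the series" means these few. Any claim that something is new, unique, unknown or untested is made for them only; others in the source may bear on it.

Measured so far in an ADME assay on MT4 cells (Homo sapiens) for cytotoxicity, read by MTT assay, with a stated time of 5 days; on this read-out lower numbers stand for higher toxicity in this test and higher numbers for lower toxicity in this test:
compound 1 `CC(C)CN(c1ccnc(Nc2ccc(C#N)cc2)n1)c1c(F)cc(-c2ccc(C#N)cc2)cc1F` gives 241000 nM
compound 2 `CCC(C)CN(c1ccnc(Nc2ccc(C#N)cc2)n1)c1c(F)cc(-c2ccc(C#N)cc2)cc1F` gives > 255000 nM
compound 3 `N#Cc1ccc(Nc2nccc(N(c3c(F)cc(-c4ccc(C#N)cc4)cc3F)C3CCCC3)n2)cc1` gives 232000 nM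

The value of compound 2 is a limit of this assay, not a number. Compound 3 sits alongside compound 1; the gap between them is a 1.0-fold lower number from compound 1 to compound 3 (0.02 log units; within the scatter). Against compound 2 the gap is an at least 1.0-fold lower number from compound 2 to compound 3 (0.04 log units; that floor lies within the scatter), with the limit of > 255000 nM in this assay, at which 1 of the 3 values shown sits, setting the floor.

Compound 4 `CC(O)CN(c1ccnc(Nc2ccc(C#N)cc2)n1)c1c(F)cc(-c2ccc(C#N)cc2)cc1F` is not yet measured. It differs from compound 3 by 2-hydroxypropyl in place of cyclopentyl on a nitrogen on an aromatic ring. The two steps that touch the same nitrogen, isobutyl to cyclopentyl and 2-methylbutyl to cyclopentyl, both stayed within the scatter, and the step from compound 1 to compound 2 on the chain was likewise an at least 1.0-fold higher number from compound 1 to compound 2 (0.02 log units; that floor lies within the scatter). Among the measured compounds shown here, no measured step at this position has moved this assay beyond its scatter, so for compound 4 the expected step is a 1.0-fold higher number from compound 3 to compound 4 (0.01 log units; within the scatter), no change beyond the scatter. Compound 4 is estimated at 235000 nM, between 110000 nM and 260000 nM.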

Compound 4, half-maximal cytotoxic concentration: 9800 nM
Compound 4: the middle estimate sits 24-fold (1.38 log units) above what was measured; measured number below the stated range.
By their numbers in this assay, from the lowest: compound 4; then compounds 3 and 1 (each within the scatter of the next). At a limit, above all of these: compound 2.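

Among the compounds shown here, this nitrogen on an aromatic ring is not indifferent in this assay: swapping cyclopentyl for 2-hydroxypropyl gives a 24-fold lower number from compound 3 to compound 4 (1.37 log units; beyond the scatter), the first step at this position to lie beyond the scatter. The open chains show the same picture, with a 25-fold lower number from compound 1 to compound 4 (1.39 log units; beyond the scatter) and an at least 26-fold lower number from compound 2 to compound 4 (1.41 log units; beyond the scatter), so hydroxy in place of methyl or ethyl on the saturated chain carbon carries a large step, where every step among the all-carbon groups stayed within the scatter. The value of compound 2 is a limit, not a number: the limit of > 255000 nM in this assay, at which 1 of the 4 values shown sits.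

Nothing measured here gives a cause for this step. Still open, as far as these compounds go, is whether the step follows the hydroxy itself, which a methoxy, an amine or a carboxylic acid on the same chain, or a hydroxy on a longer chain, would test.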